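Thiophene series: a chlorine-bearing group on the shared core

The source may report more compounds than this note shows. Statements on the series, on what has been measured and on what is new or still open speak of the compounds shown alone.

In a functional assay on cardiac atrium (Cavia porcellus) (on this read-out lower numbers stand for an effect already at smaller amounts and higher numbers for an effect only at larger amounts of compound), compound 1 `COC(=O)C1=C(C)NC(C)=C(C(=O)OC)C1c1c(-c2cccs2)nc2sccn12` gives 1300 nM and compound 2 `COC(=O)C1=C(C)NC(C)=C(C(=O)OC)C1c1c(-c2ccsc2)nc2sccn12` gives 1060 nM, so the two stand level within the scatter. Compound 3 `COC(=O)C1=C(C)NC(C)=C(C(=O)OC)C1c1c(-c2c(Cl)csc2Cl)nc2sccn12` has not yet been measured. It keeps the shared core of compound 2 but exchanges the thiophen-3-yl on an aromatic carbon of the five-membered aromatic ring with 2 nitrogen: a group of 7 heavy atoms (4 carbon, 1 sulfur, 2 chlorine; one five-membered aromatic ring with 1 hetero atom) in place of a group of 5 heavy atoms (4 carbon, 1 sulfur; one five-membered aromatic ring with 1 hetero atom), on an aromatic carbon.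

Among the compounds with values here, only one measured step bears on this change, a 1.2-fold lower number from compound 1 to compound 2 (0.09 log units; within the scatter), and it lies within the scatter. Within the data shown here, that step exchanges thiophen-2-yl for thiophen-3-yl, and no chlorine-bearing compound has been measured. It therefore offers only a weak guide to size and no basis for a direction. The working expectation is no step beyond the scatter, with wide uncertainty on either side. The expected step is a 1.3-fold lower number from compound 2 to compound 3 (0.12 log units; within the scatter), an estimate that leans only slightly to one side. In this assay the estimate for compound 3 is 800 nM, with an expected range from 200 nM to 3200 nM.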

Compound 3, half-maximal effective concentration: 2160 nM
Compound 3: the middle estimate sits 2.7-fold (0.43 log units) below what was measured, within the range that was stated.
By their numbers in this assay, from the lowest: compounds 2, 1 and 3 (each within the scatter of the next, the first and the last beyond it).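

In this assay, the position on the aromatic carbon of the five-membered aromatic ring with 2 nitrogen now shows a step beyond the scatter: the chlorine-bearing group in place of thiophen-3-yl gives a 2.0-fold higher number from compound 2 to compound 3 (0.31 log units; beyond the scatter) and that step is modest, whereas the earlier exchange of thiophen-2-yl for thiophen-3-yl stayed within the scatter. Set against thiophen-2-yl, the same group gives a 1.7-fold higher number from compound 1 to compound 3 (0.22 log units; within the scatter) and this stays within the scatter, so compound 1 and compound 3 stand level and the reading of the change depends on which thiophene serves as the reference. No measurement on these compounds accounts for the step from thiophen-3-yl to the chlorine-bearing group.

Still open, on these data alone, is whether a thiophene carrying a single chlorine would stand with compound 2 or with compound 3, which would show whether one chlorine is enough for the step. Also open, as far as these compounds go, is how this position responds to groups that are not thiophenes at all, such as a plain phenyl ring, an amine or a carboxylic acid, on the same shared core.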